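A chloro for ethyl swap in an arylsulfonate amide series

The source may report more compounds than this note shows. Statements on the series, on what has been measured and on what is new or still open speak of the compounds shown alone.

Three compounds share one core, a sulfonate ester of an isopropyl-substituted phenol joined to an anilide, and differ only in the acyl group on the amide nitrogen. Compound 1 `CCCC(=O)Nc1cccc(S(=O)(=O)Oc2ccccc2C(C)C)c1` gives 20000 nM in a functional assay on M21 cells (Homo sapiens) for antiproliferative activity, read by sulforhodamine B assay, with a stated time of 48 h (a lower number here means a stronger inhibitor, a higher number a weaker inhibitor), the highest of the three numbers. Compound 2 `CCCCCC(=O)Nc1cccc(S(=O)(=O)Oc2ccccc2C(C)C)c1` gives 11000 nM, and compound 3 `CC(C)c1ccccc1OS(=O)(=O)c1cccc(NC(=O)C(C)(C)C)c1` gives 13000 nM. The step of a 1.8-fold lower number from compound 1 to compound 2 (0.26 log units; within the scatter) and the step of a 1.5-fold lower number from compound 1 to compound 3 (0.19 log units; within the scatter) both stay within the scatter, as does a 1.2-fold higher number from compound 2 to compound 3 (0.07 log units; within the scatter), so lengthening or branching the acyl chain has produced no clear movement in this assay.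

Compound 4 `CC(C)c1ccccc1OS(=O)(=O)c1cccc(NC(=O)CCl)c1` is the next step from compound 1: chloro in place of ethyl on a saturated chain carbon bound to a carbonyl carbon. Among the measured compounds shown here, none of the measured steps introduces a chlorine or shortens the chain to a single carbon, so they bear on this change only in showing that alterations of the acyl group have so far stayed within the scatter. Compound 4 is therefore expected to land near compound 1, the step of a 2.0-fold lower number from compound 1 to compound 4 (0.30 log units; within the scatter) being an estimate with wide uncertainty. The estimated value for compound 4 is 10000 nM, with a range from 2000 nM to 40000 nM.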

Compound 4, half-maximal inhibitory concentration: 3900 nM
For compound 4 the middle estimate is 2.6-fold (0.41 log units) above the measured one; the measured number falls inside the stated range.
By their numbers in this assay, from the lowest: compound 4; then compounds 2, 3 and 1 (each within the scatter of the next).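

Until now, every change to the acyl group in this assay stayed within the scatter, but chloro in place of ethyl on this saturated chain carbon moves the number beyond it (  a 5.1-fold lower number from compound 1 to compound 4 (0.71 log units; beyond the scatter)  ), and compound 4 also separates from the other two compounds (  a 3.3-fold lower number from compound 3 to compound 4 (0.52 log units; beyond the scatter)  ;  a 2.8-fold lower number from compound 2 to compound 4 (0.45 log units; beyond the scatter)  ). The group on the carbonyl carbon can therefore change the result: compounds 1, 2 and 3, with propyl, pentyl and tert-butyl, stay within the scatter of one another, while compound 4, with chloromethyl, has the lowest number of the four. Nothing shown here explains why this swap shifts the number.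

On these data alone, it remains open whether the shift belongs to the chlorine itself or simply to the shorter group, a question that a plain methyl, a fluoro, a bromo, a hydroxyl or an amine on the same carbon could help to settle. As far as these compounds go, it is also open whether the chloromethyl group would give a step of similar size on a core other than the one shared by these four compounds.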